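Notes on the series: from compound 2 toward compound 3

A few compounds are considered here, and "the series" means these few. Any claim that something is new, unique, unknown or untested is made for them only; others in the source may bear on it.

Compound 1 `COC1(c2cc(Sc3ccc4c(c3)CCC(=O)N4C)cc(F)c2C)CCOCC1` and compound 2 `COC1(c2cc(Sc3ccc(N(C)C(C)=O)cc3)cc(F)c2C)CCOCC1` share one core and differ only in the group carried on the sulfur-linked aryl ring. In a functional assay on blood for inhibition of Polyunsaturated fatty acid 5-lipoxygenase (Homo sapiens) (a lower number here means a stronger inhibitor, a higher number a weaker inhibitor), compound 1 gives 60 nM, and in this assay compound 2 gives 30 nM. Compound 2 holds the lowest of the two numbers, yet its gap to compound 1 lies within the scatter, so the two cannot be told apart on these data.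

Compound 3 `COC1(c2cc(Sc3ccc(/C(C)=N/O)cc3)cc(F)c2C)CCOCC1` is not yet measured. It differs from compound 2 in one place: a group of 4 heavy atoms (2 carbon, 1 nitrogen, 1 oxygen; no ring) in place of a group of 5 heavy atoms (3 carbon, 1 nitrogen, 1 oxygen; no ring), on an aromatic carbon. Within the data shown here, no measured pair shows this change, so nothing supports a step beyond the scatter in either direction. The expected step is a 1.2-fold higher number from compound 2 to compound 3 (0.07 log units; within the scatter) in this assay, none beyond the scatter. Compound 3 is estimated at 35 nM, with a range from 12 nM to 100 nM.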

Compound 3, half-maximal inhibitory concentration: 20 nM
Compound 3: the middle estimate sits 1.8-fold (0.24 log units) above what was measured; low and high end bracket the measured number.
By their numbers in this assay, from the lowest: compounds 3, 2 and 1 (each within the scatter of the next, the first and the last beyond it).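

Exchanging acetyl(methyl)amino for the hydroxyimino-ethyl group, on an aromatic carbon para to a large group, gives a 1.5-fold lower number from compound 2 to compound 3 (0.18 log units; within the scatter) in this assay. This position therefore accepts an open-chain group with 1 hydrogen-bond donor and 2 hydrogen-bond acceptors in place of one with 0 hydrogen-bond donors and 1 hydrogen-bond acceptor, with no difference that these data can resolve. No supporting data bear on this result.

On these data alone, whether a carboxylic acid, a primary amine or a longer chain on this carbon would stay within the same range remains open. Also open, as far as these compounds go, is how the oxime with the opposite double-bond geometry, or its methyl ether, would compare with compound 3 in this assay.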